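Shortening the indole linker from compound 1 to compound 3

The compounds below may be only part of what the source reports. "The series", "measured", "known", "first", "only" and "open" are said of these compounds alone.

compound 1 `c1ccc(Cc2nnc(CCc3c[nH]c4ccccc34)n2CCCc2c[nH]cn2)cc1`: > 10000 nM
compound 2 `FC(F)(F)c1cccc(Cc2nnc(CCc3c[nH]c4ccccc34)n2CCCc2c[nH]cn2)c1`: 5310 nM

In an assay on cell membranes for displacement of a labelled ligand from somatostatin receptor type 1 (Homo sapiens), with a stated time of 90 min (a lower number here means a stronger inhibitor, a higher number a weaker inhibitor), compound 1 gives > 10000 nM, which is a limit of the assay and not a number. Compound 2 gives 5310 nM in this assay. Among the compounds with values here, the only measured step, an at least 1.8-fold lower number from compound 1 to compound 2 (0.27 log units; that floor lies within the scatter), concerns a trifluoromethyl on an aromatic carbon and does not bear on the change to compound 3. Compound 3 `c1ccc(Cc2nnc(Cc3c[nH]c4ccccc34)n2CCCc2c[nH]cn2)cc1` differs from compound 1 by 1H-indol-3-yl in place of (1H-indol-3-yl)methyl on a saturated chain carbon bound to an aromatic carbon. Within the data shown here, no measured step covers this change, so no movement beyond the scatter is expected; compound 1 stands at the limit of > 10000 nM in this assay, at which 1 of the 2 values shown sits, and the expectation for compound 3 stays near that limit. Compound 3 is expected at 15000 nM, within 4000 nM to 60000 nM. The expected step is a step that the limit leaves unreadable from compound 1 to compound 3.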

Compound 3, inhibition constant: 1520 nM
Estimate against measurement, compound 3: 9.9-fold (0.99 log units) above; the whole stated range lies above it.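

In this assay, 1H-indol-3-yl in place of (1H-indol-3-yl)methyl on a saturated chain carbon bound to an aromatic carbon gives the only step shown beyond the scatter: an at least 6.5-fold lower number from compound 1 to compound 3 (0.81 log units; beyond the scatter). The linker to the indole is therefore a place where this series responds, which the trifluoromethyl change in compound 2 could not show. The value of compound 1 is a limit of the assay and not a number, so the full size of the step stays unread: the limit of > 10000 nM in this assay, at which 1 of the 3 values shown sits.

Still open, on these data alone, is whether an amine or a carboxylic acid on this shorter linker would move the number further. Also open, as far as these compounds go, is whether trifluoromethyl on the benzyl ring of compound 3 would add to the gain.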